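Replacing the fluorophenyl of compound 1 with an indazole

The source may report more compounds than this note shows. Statements on the series, on what has been measured and on what is new or still open speak of the compounds shown alone.

Compound 1 `CNC(=O)c1cc(C(=O)NC2CC2)cn(Cc2ccc(F)cc2)c1=O`: 3.2
Compound 2 `CNC(=O)c1cc(C(=O)NCCC2CCOCC2)cn(Cc2ccccc2)c1=O`: 3.6
Compound 3 `CNC(=O)c1cc(C(=O)NC(C)C)cn(Cc2ccccc2)c1=O`: 3.6

Of the compounds shown here, three sharing one core have been measured in a physicochemical assay for lipophilicity, at pH 7.4; a lower number here means a more polar compound, a higher number a more lipophilic compound. Compound 1 gives 3.2, the lowest of the three. Compound 2 gives 3.6 and compound 3 gives 3.6, each standing higher than compound 1 by more than the scatter. For the measured compounds named here, the one step between neighbours, no change at the digits printed from compound 2 to compound 3 (within the scatter), concerns the amide-type nitrogen and not the group on the saturated chain carbon bound to the aromatic nitrogen.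

Compound 4 `CNC(=O)c1cc(C(=O)NC2CC2)cn(Cc2cccc3[nH]ncc23)c1=O` differs from compound 1 in exactly that place: 1H-indazol-4-yl in place of 4-fluorophenyl on a saturated chain carbon bound to an aromatic nitrogen. Going by the values given here, no measured pair shows this change or any change at this position, so there is no step to lean on; what is known is only the position of compound 1 and what leaves and what enters. On that basis the writer expects compound 4 to come out lower than compound 1, with a step of a number 0.60 log units lower from compound 1 to compound 4 (beyond the scatter). For compound 4 he estimates 2.6, within a range from 2.1 to 3.1.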

Compound 4, distribution coefficient: 1.5
For compound 4 the middle estimate is 1.10 log units above the measured one, outside the stated range (below it).
By their numbers in this assay, from the lowest: compound 4; then compound 1; then compounds 2 and 3 (each within the scatter of the next).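

The position on a saturated chain carbon bound to an aromatic nitrogen had shown no step so far, and in this assay the change from 4-fluorophenyl to 1H-indazol-4-yl now gives a number 1.70 log units lower from compound 1 to compound 4 (beyond the scatter) at that place. For the compounds shown here, the only earlier step, no change at the digits printed from compound 2 to compound 3 (within the scatter) at the amide-type nitrogen, gave no sign of a shift of this size, so the group at this position can move the number substantially, at least in this one pair. The entering group carries 1 hydrogen-bond donor and 1 hydrogen-bond acceptor and the leaving group none, but no measurement given here identifies what accounts for the step.

From the compounds shown here alone, whether the same change gives a similar step with isopropyl on the amide-type nitrogen remains open. Also open, going by these compounds, is where a pyridyl or a hydroxyphenyl group at this position would fall.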